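Chloro-to-Hydrogen Swaps on Two Aromatic Rings

This account rests on a few compounds, and the source may have more. Where it says the series, first, only, none or still open, it means among the compounds named here.

Of the compounds shown here, three of the study have been tested in a functional assay on MGC-803 cells (Homo sapiens) for inhibition, read by MTT assay, with a stated time of 72 h; a higher number here means a weaker inhibitor, a lower number a stronger inhibitor. Compound 1 `CC(C)c1ccc(-c2nc(SCc3cn(CC(=O)NC(=O)Nc4ccccn4)nn3)nc(Nc3cccc(Cl)c3)c2C#N)cc1` reaches only the limit of this assay, > 64000 nM. Its value sits at the limit of > 64000 nM in this assay, at which 1 of the 3 values shown sits. Compound 2 `CC(C)c1ccc(-c2nc(SCc3cn(CC(=O)NC(=O)Nc4ccccn4)nn3)nc(Nc3ccccc3)c2C#N)cc1` differs from compound 1 by hydrogen in place of chloro on an aromatic carbon, and in this assay compound 2 gives 15800 nM, so that the step of an at least 4.0-fold lower number from compound 1 to compound 2 (0.60 log units; beyond the scatter) is clearly seen. Compound 3 `Cc1ccc(Nc2nc(SCc3cn(CC(=O)NC(=O)Nc4ccccn4)nn3)nc(-c3ccc(Cl)cc3)c2C#N)cc1` has a different core; the difference between the cores of compound 1 and compound 3 is not broken down here. In this assay compound 3 gives 24000 nM, a value that lies within the scatter of that of compound 2.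

Compound 4 `Cc1ccc(Nc2nc(SCc3cn(CC(=O)NC(=O)Nc4ccccn4)nn3)nc(-c3ccccc3)c2C#N)cc1` is not yet measured. It differs from compound 3 by hydrogen in place of chloro on an aromatic carbon. This is the same kind of change as that from compound 1 to compound 2, but not the same: there the chloro sat meta to a large group, here it sits para to a large group, and the two cores are not the same.

For compound 4 in this assay, a lower number than that of compound 3 is expected, since the step of an at least 4.0-fold lower number from compound 1 to compound 2 (0.60 log units; beyond the scatter) went that way and compound 3 starts from 24000 nM; the expected step is a 2.4-fold lower number from compound 3 to compound 4 (0.38 log units; beyond the scatter), taken as smaller than the measured one. Compound 4 is therefore estimated at 10000 nM, with a likely range from 3500 nM to 28000 nM.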

Compound 4, half-maximal inhibitory concentration: 7870 nM
Compound 4: middle estimate off by 1.3-fold (0.10 log units), on the high side; low and high end bracket the measured number.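

In this assay, going from the 4-chlorophenyl to the phenyl group gives a 3.0-fold lower number from compound 3 to compound 4 (0.48 log units; beyond the scatter), so hydrogen in place of chloro on an aromatic carbon lowers the number on both cores, and the direction of the change carries over within these two pairs: the same change on two cores in this assay, an at least 4.0-fold lower number (0.60 log units; beyond the scatter) from compound 1 to compound 2 and a 3.0-fold lower number (0.48 log units; beyond the scatter) from compound 3 to compound 4; the limit leaves it open whether they differ The value of compound 1, > 64000 nM, is a limit of the assay and not a number. The two pairs therefore show a shared direction but not a shared size, and with the chloro on a different aromatic ring in each pair, they do not show that the change would act the same way on other cores or at other places in this series.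

The compounds shown leave open how a fluoro, a methoxy or an amine would compare with chloro and hydrogen on the aromatic carbon of the 4-chlorophenyl group. They also leave open whether the same direction would hold with a carboxylic acid or a longer chain elsewhere on these aromatic rings, since only chloro and hydrogen are compared here, in just two pairs and in a single assay.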